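The source may report more compounds than this note shows. Statements on the series, on what has been measured and on what is new or still open speak of the compounds shown alone.

In an ADME assay on MT4 cells (Homo sapiens) for cytotoxicity, read by MTT assay, with a stated time of 4 days (on this read-out lower numbers stand for higher toxicity in this test and higher numbers for lower toxicity in this test), compound 1 (`CC(=O)Nc1ccc2oc(-c3cccc(F)c3)c(O)c(=O)c2c1`) gives 26500 nM and so sits in the upper pair of the three measured numbers. Compound 3 (`Nc1ccc2oc(-c3cccc(F)c3)c(O)c(=O)c2c1`) gives 35300 nM and lies within the scatter of compound 1, whereas compound 2 (`CC(=O)Nc1ccc2oc(-c3cccc(C(F)(F)F)c3)c(O)c(=O)c2c1`) gives 5700 nM and stands clearly apart. Compound 4 (`COc1c(-c2cccc(F)c2)oc2ccc(NC(C)=O)cc2c1=O`) has not yet been measured and differs from compound 1 by one change, methyl in place of hydrogen on an oxygen on an aromatic ring with hydroxy becoming methoxy.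

Neither measured step touches that oxygen. Trifluoromethyl in place of fluoro on an aromatic carbon gave a 4.6-fold lower number from compound 1 to compound 2 (0.67 log units; beyond the scatter) and counts as modest, while hydrogen in place of acetyl on a nitrogen on an aromatic ring gave a 1.3-fold higher number from compound 1 to compound 3 (0.12 log units; within the scatter) as its result. These steps show that one change elsewhere can either move the number or leave it in place, but they say nothing direct about this one. No step beyond the scatter is therefore expected, and the expected move is a 1.2-fold lower number from compound 1 to compound 4 (0.08 log units; within the scatter) with wide uncertainty. For compound 4 the estimated value is 22000 nM (expected range 8000 nM to 60000 nM).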

Compound 4, half-maximal cytotoxic concentration: 210000 nM
The estimate for compound 4 lay 9.5-fold (0.98 log units) below the measured number; measured number outside the range, above it.
By their numbers in this assay, from the lowest: compound 2; then compounds 1 and 3 (each within the scatter of the next); then compound 4.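

Methyl in place of hydrogen on this oxygen gives a 7.9-fold higher number from compound 1 to compound 4 (0.90 log units; beyond the scatter) in this assay, so the hydroxy is a place where a single small change moves the number beyond the scatter. The direction is towards lower toxicity in this test, the opposite of the trifluoromethyl step, which gave a 4.6-fold lower number from compound 1 to compound 2 (0.67 log units; beyond the scatter). No information here explains why adding this one methyl has such an effect.

On these data alone, it stays open whether the loss of the hydrogen or the arrival of the methyl matters more, and whether a longer chain such as ethyl, or an acetyl on the same oxygen, would move the number as far. The compounds shown also leave open whether hydroxy to methoxy would act the same way with trifluoromethyl in place of fluoro, or with the free amine in place of the acetyl amide.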